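The source may hold more compounds than are shown below. What is called first, only, known or untested is meant among the compounds shown, and "the series" means these compounds.

Measured compounds in a functional assay on HCT-15 cells (Homo sapiens) for cytotoxicity, read by CCK-8 assay and cell counting, with a stated time of 2 days; on this read-out lower numbers stand for stronger inhibition and higher numbers for weaker inhibition:
compound 1 `Oc1ccc(-c2cc(-c3ccc(Cl)cc3)nc(-c3ccsc3)c2)cc1`, 6240 nM
compound 2 `Oc1cccc(-c2cc(-c3ccc(Cl)cc3)nc(-c3ccsc3)c2)c1`, 8850 nM
compound 3 `Oc1cccc(-c2cc(-c3ccsc3)nc(-c3cccc(Cl)c3)c2)c1`, 2510 nM

Compound 2 gives the highest of the three numbers in this assay. Its nearest neighbour is compound 1, with a 1.4-fold higher number from compound 1 to compound 2 (0.15 log units; within the scatter); its furthest is compound 3, with a 3.5-fold lower number from compound 2 to compound 3 (0.55 log units; beyond the scatter).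

Compound 4 `Oc1cccc(-c2cc(-c3ccc(Cl)cc3)nc(-c3ccco3)c2)c1` has not been measured. It differs from compound 2 by furan-2-yl in place of thiophen-3-yl on an aromatic carbon.

Neither measured step touches this part of the shared core: the step from compound 1 to compound 2 moves the hydroxyl on the hydroxyphenyl group, and the step from compound 2 to compound 3 moves the chlorine on the chlorophenyl group. Within the data shown here, the thiophen-3-yl group is the same in all three measured compounds, so there is no precedent for exchanging it. With nothing to go on, no step beyond the scatter is expected in this assay for compound 4, and the estimate stays close to compound 2, with the range widened to cover the lack of precedent: a 1.1-fold lower number from compound 2 to compound 4 (0.04 log units; within the scatter).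

Compound 4 is therefore expected to give 8000 nM in this assay, in the range 2500 nM to 25000 nM.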

Compound 4, half-maximal inhibitory concentration: 10200 nM
For compound 4 the middle estimate is 1.3-fold (0.11 log units) below the measured one, within the range that was stated.
By their numbers in this assay, from the lowest: compound 3; then compounds 1, 2 and 4 (each within the scatter of the next).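

Among these compounds, the earlier compounds all carry thiophen-3-yl, so the only reading at this position, next to the ring nitrogen, is the exchange for furan-2-yl, which in this assay gives a 1.2-fold higher number from compound 2 to compound 4 (0.06 log units; within the scatter) and so does not separate the two groups. At this position, one five-membered aromatic ring with 1 hetero atom can therefore replace another, with oxygen for sulfur and a different point of attachment, without a step beyond the scatter in this read-out. Nothing measured here gives a reason for this result.

The compounds shown leave open whether an unsubstituted phenyl, an amine or a longer alkyl chain at this position would move the number beyond the scatter. Also open, from the compounds shown here alone, is whether the step seen with thiophen-3-yl, a 3.5-fold lower number from compound 2 to compound 3 (0.55 log units; beyond the scatter), carries over to the furan-2-yl series.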